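A few compounds are considered here, and "the series" means these few. Any claim that something is new, unique, unknown or untested is made for them only; others in the source may bear on it.

In a functional assay on PC-3 cells (Homo sapiens) for inhibition, with a stated time of 72 h (on this read-out lower numbers stand for stronger inhibition and higher numbers for weaker inhibition), compound 1 `Cc1cc(Cl)ccc1NC(=O)Nc1nc(Sc2c[nH]c3ccccc23)cc(N2CCN(Cc3ccccc3)CC2)n1` gives 22500 nM, the only numerical value among the two results shown. Compound 2 `Cc1ccc(C)c(NC(=O)Nc2nc(Sc3c[nH]c4ccccc34)cc(N3CCCCC3)n2)c1` reaches only the assay limit of > 50000 nM in this assay; this is the limit of > 50000 nM in this assay, at which 1 of the 2 values shown sits, at which one of the two values sits. Compound 3 `O=C(Nc1ccccc1)Nc1nc(Sc2c[nH]c3ccccc23)cc(N2CCN(Cc3ccccc3)CC2)n1` differs from compound 1 by phenyl in place of 4-chloro-2-methylphenyl on an amide-type nitrogen. Going by the values given here, no step between measured compounds is available, so the step from compound 1 to compound 3 is estimated from compound 1 alone: a moderate loss, a 1.8-fold higher number from compound 1 to compound 3 (0.25 log units; within the scatter), leaning toward weaker inhibition. Compound 3 is therefore expected to show 40000 nM in this assay, within 15000 nM to 100000 nM.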

Compound 3, half-maximal inhibitory concentration: 42500 nM
Compound 3: middle estimate off by 1.1-fold (0.03 log units), on the low side; the range from low to high includes it.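

In this assay, going by these compounds alone, phenyl in place of 4-chloro-2-methylphenyl on an amide-type nitrogen gives a 1.9-fold higher number from compound 1 to compound 3 (0.28 log units; within the scatter) and so provides the first measured step at this position. Taking off the chlorine and the methyl together thus leaves the read-out within the usual scatter for this one pair. Nothing measured here bears on a cause for this step. On these data alone, whether an amine, a methoxy group or a carboxylic acid on this phenyl ring would move the number beyond the scatter stays open. So does the contribution of the chlorine and the methyl taken singly.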